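The source may hold more compounds than are shown below. What is called first, only, known or untested is meant among the compounds shown, and "the series" means these compounds.

In a functional assay on DU-145 cells (Homo sapiens) for cytotoxicity, read by MTT assay (a lower number here means a stronger inhibitor, a higher number a weaker inhibitor), compound 1 `CC[C@](C)(O)CC(=O)O[C@H](CC=C(C)C)C1=CC(=O)c2c(O)ccc(O)c2C1=O` gives 20500 nM and compound 2 `CCCC(C)(O)CC(=O)O[C@H](CC=C(C)C)C1=CC(=O)c2c(O)ccc(O)c2C1=O` gives 75000 nM as the higher of the two numbers. Compound 3 `CCC(CO[C@H](CC=C(C)C)C1=CC(=O)c2c(O)ccc(O)c2C1=O)OC` differs from compound 2 by 2-methoxybutyl in place of (2-hydroxy-2-methylpentyl)carbonyl on an oxygen on a saturated carbon in one swap: 2-methoxybutyl in place of (2-hydroxy-2-methylpentyl)carbonyl on an oxygen on a saturated carbon. Among the measured compounds shown here, the only measured step, a 3.7-fold higher number from compound 1 to compound 2 (0.56 log units; beyond the scatter), is modest and covers a far smaller change, so it is a weak guide. A step of similar size toward a lower number is expected, namely a 2.5-fold lower number from compound 2 to compound 3 (0.40 log units; beyond the scatter) in the estimate. Compound 3 is estimated at 30000 nM with 8000 nM to 100000 nM as the expected range.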

Compound 3, half-maximal inhibitory concentration: 45700 nM
Estimate against measurement, compound 3: 1.5-fold (0.18 log units) below; low and high end bracket the measured number.
By their numbers in this assay, from the lowest: compound 1; then compounds 3 and 2 (each within the scatter of the next).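

In this assay, 2-methoxybutyl in place of (2-hydroxy-2-methylpentyl)carbonyl gives a 1.6-fold lower number from compound 2 to compound 3 (0.22 log units; within the scatter), so a smaller group without a hydrogen-bond donor still gives a number matching that of compound 2. Against (2-hydroxy-2-methylbutyl)carbonyl, the same 2-methoxybutyl gives a 2.2-fold higher number from compound 1 to compound 3 (0.35 log units; beyond the scatter), so that group keeps a measurable edge. Nothing available explains either step.

Still open, going by these compounds, is whether an amine or a carboxylic acid on this oxygen on a saturated carbon would shift the number beyond the scatter. On these data alone, a longer chain in place of 2-methoxybutyl is equally open.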